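Methoxy on the phenyl ring of compound 3

A few compounds are considered here, and "the series" means these few. Any claim that something is new, unique, unknown or untested is made for them only; others in the source may bear on it.

In an ADME assay on BHK-21 cells (Mesocricetus auratus) for cytotoxicity, read by MTT assay (a lower number here means that less compound is tolerated, a higher number that more compound is tolerated), compound 1 `COc1ccc(-c2nc3cc(C(C)O)ccc3[nH]2)cc1` gives > 100000 nM, which is a limit and not a number. Compound 2 `C/C(=N\NC(N)=O)c1ccc2[nH]c(-c3ccccc3)nc2c1` gives > 100000 nM, again a limit. For the measured compounds named here, compound 3 `C/C(=N\NC(N)=S)c1ccc2[nH]c(-c3ccccc3)nc2c1` gives 32000 nM, the only actual number in the set, so it cannot be ranked against a spread of measured values.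

Compound 4 `COc1ccc(-c2nc3cc(/C(C)=N/NC(N)=S)ccc3[nH]2)cc1` is compound 3 with one change, methoxy in place of hydrogen on an aromatic carbon, para to a large group, turning phenyl into 4-methoxyphenyl.

Going by the values given here, the only measured step is an at least 3.1-fold lower number from compound 2 to compound 3 (0.49 log units; beyond the scatter). It concerns the group on the amine nitrogen, not the new methoxy, and compound 4 keeps the sulfur-bearing group of compound 3. That step therefore bears only indirectly, and it sets no size for the present change. Among the compounds with values here, compound 1 also carries 4-methoxyphenyl, but no measured pair isolates that group.

The anchor is therefore compound 3 at 32000 nM, and no shift beyond the scatter is expected in this assay. The expected step is a 1.1-fold higher number from compound 3 to compound 4 (0.04 log units; within the scatter). For compound 4 the estimated value is 35000 nM, with an expected range of 14000 nM to 90000 nM.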

Compound 4, half-maximal cytotoxic concentration: 13000 nM
Compound 4: middle estimate off by 2.7-fold (0.43 log units), on the high side; the measured number lies below the stated range.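

In this assay, the change from phenyl to 4-methoxyphenyl now has a measured effect on this series: a 2.5-fold lower number from compound 3 to compound 4 (0.39 log units; beyond the scatter). Methoxy at this place, para to a large group, therefore moves the number beyond the scatter towards less compound tolerated, at least when the sulfur-bearing group is present. With 4-methoxyphenyl held constant, the group on the aromatic carbon of the shared core also matters, as shown by an at least 7.6-fold lower number from compound 1 to compound 4 (0.88 log units; beyond the scatter), and only the sulfur-bearing compound 3 and compound 4 give actual numbers, while compound 1 and compound 2 each stand at a limit and not at a number: the limit of > 100000 nM in this assay, at which 2 of the 4 values shown sit.

For the compounds shown here, whether methoxy has any effect without the sulfur-bearing group stays open, since the limit of compound 2 leaves no measured pair for that change. Also open, going by these compounds, is whether ethoxy, hydroxyl or chlorine at the same place would give a step of similar size, or whether an amine there would move the number the other way.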